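The source may hold more compounds than are shown below. What is called first, only, known or untested is meant among the compounds shown, and "the series" means these compounds.

In an ADME assay on cells (Homo sapiens) for cytotoxicity, read by polymerase chain reaction, with a stated time of 3 days (on this read-out higher numbers stand for lower toxicity in this test and lower numbers for higher toxicity in this test), compound 1 `Nc1nc(Cl)c(-c2nccs2)c(N[C@@H]2C[C@H](CO)[C@@H](O)[C@H]2O)n1` gives > 25000 nM, which is a limit of the assay and not a number. Among the compounds with values here, compound 2 `CCNc1nc(C)c(-c2nc3ccccc3s2)c(N[C@@H]2C[C@H](CO)[C@@H](O)[C@H]2O)n1` gives 12000 nM, the only true number so far, so it offers a single firm reference point and no ranking along a scale. Compound 3 `Cc1nc(N(C)C)nc(N[C@@H]2C[C@H](CO)[C@@H](O)[C@H]2O)c1-c1nc2ccccc2s1` has not yet been measured. It carries the same atoms as compound 2, joined differently: dimethylamino in place of ethylamino on an aromatic carbon. In words, dimethylamino stands in place of ethylamino on an aromatic carbon, and the rest of the molecule stays the same. Within the data shown here, no two measured compounds differ in one place only, so the data do not show what a swap of this kind does in this assay. The best available guide is therefore compound 2 itself, at 12000 nM. The expected step of no change at the digits printed from compound 2 to compound 3 (within the scatter) is no larger than the usual scatter of repeated measurements, and no direction can be favoured. For compound 3, the estimated value is 12000 nM, with an expected range from 6000 nM to 24000 nM.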

Compound 3, half-maximal cytotoxic concentration: 18000 nM
The estimate for compound 3 lay 1.5-fold (0.18 log units) below the measured number; the measured number falls inside the stated range.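

The one-place change from ethylamino to dimethylamino, on an aromatic carbon between two ring nitrogen atoms, gives in this assay a 1.5-fold higher number from compound 2 to compound 3 (0.18 log units; within the scatter), so the two compounds cannot be told apart in this test. The swap keeps the count of 3 heavy atoms but goes from 1 hydrogen-bond donor to 0 hydrogen-bond donors, and in this single pair that difference does not separate the read-outs beyond the usual scatter. Neither compound 2 nor compound 3 sits at a limit, so this first comparison rests on two true numbers, which compound 1 could not supply: the limit of > 25000 nM in this assay, at which 1 of the 3 values shown sits.

Still open, on these data alone, is whether a bigger change at this same position, such as a longer chain like butylamino or a cyclic amine like morpholine, would move the number beyond the scatter. Compound 1 differs from compound 2 and compound 3 in more than one place, so it says nothing about the group at this position, and one pair cannot show whether the result holds on other versions of the shared core.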